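The source may hold more compounds than are shown below. What is called first, only, known or untested is meant among the compounds shown, and "the series" means these compounds.

Compound 1 `Cc1ccc([C@@H]2CN(C)[C@]3(C(=O)Nc4ccccc43)[C@]23Cc2ccccc2C3=O)cc1` gives 17.1% in a functional assay on the whole organism (strain Wister albino) for inhibition, with Rattus norvegicus as the target, read by paw edema, with stated times of 1 h and 4 h, at a dose of 50 mg/kg by the intraperitoneal route; a lower number here means less inhibition, a higher number more inhibition at the dose given (going by the name of the read-out).
Compound 2 `CN1C(=O)[C@@]2(c3ccccc31)N(C)C[C@@H](c1ccco1)[C@@]21Cc2ccccc2C1=O` gives 8.2%.
Compound 3 `CN1C(=O)[C@@]2(c3ccccc31)N(C)C[C@@H](c1ccc(Cl)cc1)[C@@]21Cc2ccccc2C1=O` gives 8.5%.

Compound 3 sits among three numbers that all lie within the scatter of one another: compound 2 is its nearest neighbour, and compound 1, the furthest, is still within the scatter of it. Compound 4 `Cc1ccc([C@@H]2CN(C)[C@]3(C(=O)N(C)c4ccccc43)[C@]23Cc2ccccc2C3=O)cc1` is the next compound and has not yet been measured in this assay. It differs from compound 3 in one place, (methyl in place of chloro on an aromatic carbon).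

For the measured compounds named here, only one measured step is available, a number 0.3 percentage points higher from compound 2 to compound 3 (within the scatter), and it concerns a different change on the same saturated ring carbon, so it bears on the present step only loosely; it shows that a swap of the aryl group at that position left the number within the scatter. Compound 1 shares the 4-methylphenyl group of compound 4 but also differs from compound 3 at the amide nitrogen, so its value can only be read as a second number in the same low band. On this footing compound 4 is expected to stay within the scatter of compound 3, giving an estimated step of a number 1.5 percentage points higher from compound 3 to compound 4 (within the scatter). Compound 4 is therefore estimated at 10%, with a range from 3% to 20%.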

Compound 4, a percentage reported as inhibition, in the whole organism at one dose (the size of the read-out at that dose, not a potency): 13.9%
For compound 4 the middle estimate is 3.9 percentage points below the measured one; the measured number falls inside the stated range.
By their numbers in this assay, from the lowest: compounds 2, 3, 4 and 1 (each within the scatter of the next).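

In this assay, methyl in place of chloro on an aromatic carbon, para to a large group, gives a number 5.4 percentage points higher from compound 3 to compound 4 (within the scatter), and 4-methylphenyl in place of furan-2-yl on the saturated ring carbon gives a number 5.7 percentage points higher from compound 2 to compound 4 (within the scatter); both steps lie within the scatter, so the aryl changes shown so far have not separated any of these compounds. The result also gives the first reading at a second position: methyl in place of hydrogen on the amide-type nitrogen in a ring gives a number 3.2 percentage points lower from compound 1 to compound 4 (within the scatter), likewise within the scatter, so neither that nitrogen nor the aryl group has yet shown a step beyond it. No measurement is at hand that would explain any of these steps.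

With all four compounds lying within the scatter of the next, their numbers set no order among them and no trend for either position. As far as these compounds go, it stays open whether an amine or a carboxylic acid in place of the methyl on the aromatic carbon, or a longer chain in place of the methyl on the amide-type nitrogen, would give a step beyond the scatter.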